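Acetyl in place of methyl on compound 3

A few compounds are considered here, and "the series" means these few. Any claim that something is new, unique, unknown or untested is made for them only; others in the source may bear on it.

Compound 1 `COc1cc(Nc2nnc(Cl)c(Nc3cc(OC)c(OC)c(OC)c3)n2)cc(OC)c1OC` is reported in a functional assay on ECa-109 cells for inhibition, with ECa-109 cell line (Homo sapiens) as the target, read by MTT assay, with a stated time of 48 h (on this read-out lower numbers stand for stronger inhibition and higher numbers for weaker inhibition), only as a limit, > 50000 nM. Compound 2 `COc1cccc(Nc2nnc(Cl)c(Nc3cc(OC)c(OC)c(OC)c3)n2)c1` gives 15900 nM. Compound 3 `COc1cc(Nc2nc(Nc3ccc(C)cc3)nnc2Cl)cc(OC)c1OC` gives 27300 nM. These two numbers stand together, with a 1.7-fold higher number from compound 2 to compound 3 (0.23 log units; within the scatter). Compound 4 `COc1cc(Nc2nc(Nc3ccc(C(C)=O)cc3)nnc2Cl)cc(OC)c1OC` carries acetyl in place of methyl on an aromatic carbon, para to a large group: acetyl in place of methyl on an aromatic carbon. Among the measured compounds shown here, only one measured step bears on this substituent, the exchange of 3-methoxyphenyl for 4-methylphenyl, and it amounted to a 1.7-fold higher number from compound 2 to compound 3 (0.23 log units; within the scatter). On that small step, no change beyond the scatter is expected in this assay, and the estimated step is a 1.4-fold lower number from compound 3 to compound 4 (0.14 log units; within the scatter). The estimate for compound 4 is 20000 nM. Its expected range runs from 8000 nM to 50000 nM.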

Compound 4, half-maximal inhibitory concentration: 36300 nM
Estimate against measurement, compound 4: 1.8-fold (0.26 log units) below; the range from low to high includes it.
By their numbers in this assay, from the lowest: compounds 2, 3 and 4 (each within the scatter of the next, the first and the last beyond it). At a limit, above all of these: compound 1.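

Acetyl in place of methyl, on an aromatic carbon para to a large group, gives a 1.3-fold higher number from compound 3 to compound 4 (0.12 log units; within the scatter), so in this assay this exchange, which adds a carbonyl, leaves no change that can be read. The 4-acetylphenyl group does separate from 3-methoxyphenyl, with a 2.3-fold higher number from compound 2 to compound 4 (0.36 log units; beyond the scatter), a modest step that 4-methylphenyl did not show. Any further move toward weaker inhibition can be followed only a short way here: the limit of > 50000 nM in this assay, at which 1 of the 4 values shown sits.

Still open, as far as these compounds go, is whether an amine or a carboxylic acid at this position would bring the number down. From the compounds shown here alone, whether a longer chain on the carbonyl would alter it also remains unknown.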